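The source may report more compounds than this note shows. Statements on the series, on what has been measured and on what is new or still open speak of the compounds shown alone.

For the measured compounds named here, in a functional assay on SW480 cells (Homo sapiens) for cytotoxicity, read by sulforhodamine B assay, with a stated time of 48 h (on this read-out higher numbers stand for weaker inhibition and lower numbers for stronger inhibition), compound 2 `COc1ccc(-c2cc(C(=O)/C=C/c3cccc(OC)c3OC)ccc2N)cc1OC` gives 8330 nM, the lowest of the three numbers so far, but compound 3 `COc1ccc(/C=C/C(=O)c2ccc(N)c(-c3ccc(OC)c(OC)c3)c2)c(OC)c1` at 9300 nM lies within the scatter of it. Compound 1 `O=C(/C=C/c1ccc(Br)cc1)c1cccc(-c2cccc(F)c2)c1` gives 18200 nM, a clearly higher number than compound 2. Compound 4 `COc1cccc(/C=C/C(=O)c2ccc(N)c(-c3ccc(F)cc3)c2)c1OC` has not yet been measured. It carries 4-fluorophenyl in place of the 3,4-dimethoxyphenyl of compound 2 on an aromatic carbon, ortho to an amino group (4-fluorophenyl in place of 3,4-dimethoxyphenyl on an aromatic carbon).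

Going by the values given here, the one measured step, a 1.1-fold higher number from compound 2 to compound 3 (0.05 log units; within the scatter), stays within the scatter, but it concerns a different group, the dimethoxyphenyl on the double-bonded chain, so it does not test this swap directly. Among the compounds with values here, the only other hint is compound 1, which also carries a fluorine and gives 18200 nM, although it differs from compound 2 in more than one place. A modest move towards weaker inhibition is therefore expected, an estimated 1.4-fold higher number from compound 2 to compound 4 (0.16 log units; within the scatter). For compound 4 the expected value is 12000 nM, with an estimated range from 5000 nM to 28000 nM.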

Compound 4, half-maximal inhibitory concentration: 12500 nM
Beside the measured number, compound 4's estimate is 1.0-fold (0.02 log units) below it; the measured number falls inside the stated range.
By their numbers in this assay, from the lowest: compounds 2, 3, 4 and 1 (each within the scatter of the next, the first and the last beyond it).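

Swapping 3,4-dimethoxyphenyl for 4-fluorophenyl on this aromatic carbon, ortho to an amino group, gives a 1.5-fold higher number from compound 2 to compound 4 (0.18 log units; within the scatter), the first direct reading of a change at this position. The entering group has 0 hydrogen-bond acceptors against 2 in the leaving group, and fewer heavy atoms, yet the step stays within the scatter, so in this one pair the position tolerates the exchange of these two aryl groups. No measurement at hand accounts for this tolerance.

On these data alone, whether a quite different group on this carbon, such as a piperidine, a carboxylic acid or a plain hydrogen, would move the number beyond the scatter remains open. So does whether 4-fluorophenyl would give a similar result alongside the 2,4-dimethoxyphenyl of compound 3.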